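Notes on compound 4: arylsulfanyl in place of chloro

The compounds below may be only part of what the source reports. "The series", "measured", "known", "first", "only" and "open" are said of these compounds alone.

Measured so far:
compound 1, `Clc1ncnc2c1ncn2Cc1ccccc1`: 0%
compound 2, `Clc1ncnc2ncn(Cc3ccccc3)c12`: 0%
compound 3, `Fc1ccc(Cn2cnc3c(Cl)ncnc32)cc1`: 0%

In an assay on isolated protein for inhibition of RAC-alpha serine/threonine-protein kinase (Homo sapiens), tested at 30 uM (a lower number here means less inhibition, a higher number more inhibition at the concentration tested (going by the name of the read-out)), compound 1 gives 0%, compound 2 gives 0% and compound 3 gives 0%. Compound 3 thus stands level with compounds 1 and 2 at the digits shown, with no separation among the three beyond the scatter. For the measured compounds named here, the one step between compounds differing in a single place, no change at the digits printed from compound 1 to compound 3 (within the scatter), is a fluoro in place of hydrogen on an aromatic carbon and left the read-out unchanged.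

Compound 4 is `Fc1ccc(Cn2cnc3c(Sc4ccc(F)cc4)ncnc32)cc1`. The change from compound 3 is (4-fluorophenyl)sulfanyl in place of chloro on an aromatic carbon. Going by the values given here, no measured step touches this position or this kind of group; the only step available concerns the fluoro and is unrelated to the chloro site, so it gives no direction for this assay. Among the compounds with values here, with every measured compound sitting at the floor of the read-out and no precedent for the sulfanyl group, the step of a number 5 percentage points higher from compound 3 to compound 4 (within the scatter) is expected to stay within the scatter. For compound 4 the estimate is 5%, with a range from 0% to 25%.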

Compound 4, a percentage reported as inhibition, at one concentration (the size of the read-out at that concentration, not a potency): 0%
Compound 4: middle estimate off by 5 percentage points, on the high side, within the range that was stated.
By their numbers in this assay, from the lowest: compounds 1, 2, 3 and 4 (each within the scatter of the next).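

In this assay, (4-fluorophenyl)sulfanyl in place of chloro, on the aromatic carbon next to the ring nitrogen, gives no change at the digits printed from compound 3 to compound 4 (within the scatter) and is the only step shown at this position. For the compounds shown here, it shows that this larger group, with its added six-membered aromatic ring and sulfur, leaves the read-out level with that of the chloro compounds at the tested concentration, whereas the earlier compounds showed only a fluoro change elsewhere on the molecule. Nothing measured here accounts for this result.

Going by these compounds, whether an amine or a carboxylic acid in place of chloro at this position would separate from compound 3 in this assay remains open. Also open is whether a longer chain on the sulfur would do so, and with all compounds shown level, the read-out does not yet rank any position of the shared core.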